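A few compounds are considered here, and "the series" means these few. Any claim that something is new, unique, unknown or untested is made for them only; others in the source may bear on it.

Two compounds built on one shared core were tested in an ADME assay on the whole organism (lung, Rattus norvegicus) for metabolic stability, read by LC-MS, with a stated time of 24 h; a lower number here means that less of the compound is left, a higher number that more of the compound is left. Compound 1 `Cc1csc2cc([C@H](C)Nc3ncnc(N)c3C#N)c(-c3cccc(CN(C)CCCN(C)Cc4ccc(Cl)cc4)c3)c(=O)n12` gives 3.3% in this assay. Compound 2 `Cc1csc2cc([C@H](C)Nc3ncnc(N)c3C#N)c(Cc3cccc(CN(C)CC(C)C)c3)c(=O)n12` gives 0%, a number so close to that of compound 1 that the two lie within the usual scatter, so neither can be set apart from the other. Compound 3 `CNCc1cccc(Cc2c([C@H](C)Nc3ncnc(N)c3C#N)cc3scc(C)n3c2=O)c1` has not yet been measured; it differs from compound 2 by hydrogen in place of isobutyl on an amine nitrogen. For the measured compounds named here, no measured pair shows what such a change does, so no step beyond the scatter is expected, and the estimated step of a number 2 percentage points higher from compound 2 to compound 3 (within the scatter) stays small. Compound 3 is expected to give 2%, between 0% and 12%.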

Compound 3, percent of the compound remaining: 0%
Compound 3: the middle estimate sits 2 percentage points above what was measured; the measured number falls inside the stated range.
By their numbers in this assay, from the lowest: compounds 2, 3 and 1 (each within the scatter of the next).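

Hydrogen in place of isobutyl on this amine nitrogen, the first change at this position that can be read in this assay, gives no change at the digits printed from compound 2 to compound 3 (within the scatter) and so offers no sign that the isobutyl group alters how much compound is left. Since compound 3 gives 0% in this assay and a lower number is not possible, only a rise could have shown an effect here. Nothing available explains this result. From the compounds shown here alone, whether an acetyl group or a cyclopropyl group on this nitrogen would leave more of the compound remains open.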